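Swapping the Aryl Ketone Ring in a Chalcone Amide

The source may report more compounds than this note shows. Statements on the series, on what has been measured and on what is new or still open speak of the compounds shown alone.

Compound 1 `COC(=O)c1cc(-c2cccc(NC(=O)c3ccc(/C=C/C(=O)c4cccc(C(F)(F)F)c4)cc3)c2)on1` was tested in an ADME assay on Vero cells (Chlorocebus sabaeus) for cytotoxicity, read by MTT assay, with a stated time of 72 h; a higher number here means that more compound is tolerated, a lower number that less compound is tolerated. In this assay compound 1 gives > 20 ug/mL, which is a limit of the assay rather than a number, so compound 1 sits at the limit of > 20 ug/mL in this assay, at which 1 of the 2 values shown sits. Compound 2 `O=C(O)c1ccc(/C=C/C(=O)c2ccc(Cl)cc2)cc1` is a smaller acid that shares only part of the core of compound 1. In this assay compound 2 gives < 10 ug/mL, again a limit and not a number. Within the data shown here, both values are limits, so no measured step between them can be given; they show only that compound 1 and compound 2 stand at opposite ends of the reported range.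

Compound 3 `COC(=O)c1cc(-c2cccc(NC(=O)c3ccc(/C=C/C(=O)c4ccc(OC)cc4OC)cc3)c2)on1` differs from compound 1 in one place: 2,4-dimethoxyphenyl in place of 3-(trifluoromethyl)phenyl on a carbonyl carbon. Among the measured compounds shown here, no measured pair of compounds shows this change, so its size is not known from these data; the expected step that the limit leaves unreadable from compound 1 to compound 3 in this assay is none beyond the usual scatter. Compound 3 is therefore estimated at 25 ug/mL, within 12 ug/mL to 60 ug/mL, and most likely to be reported as a limit once more.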

Compound 3, half-maximal cytotoxic concentration: > 50 ug/mL
Compound 3 was reported as a limit; the forecaster's own chance of this, stated with the estimate: 70%; middle value at least 2.0-fold (0.30 log units) away from the limit.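

Compound 1 and compound 3 are both reported as limits of the assay rather than as numbers, so the step between them cannot be read. The compounds shown leave open how much of either compound is actually tolerated, and whether placing 2,4-dimethoxyphenyl instead of 3-(trifluoromethyl)phenyl on the carbonyl carbon changes that tolerance at all.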